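This account rests on a few compounds, and the source may have more. Where it says the series, first, only, none or still open, it means among the compounds named here.

Working notes on the series. In a functional assay on MIA PaCa-2 cells (Homo sapiens) for antiproliferative activity, read by MTT assay, with a stated time of 72 h (a higher number here means a weaker inhibitor, a lower number a stronger inhibitor), compound 2 (`O=C1O/C(=C\Cn2cnc3ccnc(Cl)c32)C(OCc2ccccc2)=C1OCc1ccccc1`) gives > 100000 nM, which is a limit and not a number. Its standing is therefore (the limit of > 100000 nM in this assay, at which 1 of the 2 values shown sits). Going by the values given here, the only other measured member, compound 1 (`O=C1O/C(=C\Cn2cnc3cncc(Br)c32)C(OCc2ccccc2)=C1OCc1ccccc1`), gives 22600 nM. The next change leads to compound 3 (`O=C1O/C(=C\Cn2cnc3c(Cl)c(F)nc(F)c32)C(OCc2ccccc2)=C1OCc1ccccc1`): a group of 12 heavy atoms (6 carbon, 3 nitrogen, 2 fluorine, 1 chlorine; one five-membered aromatic ring with 2 hetero atoms, one six-membered aromatic ring with 1 hetero atom) in place of a group of 10 heavy atoms (6 carbon, 3 nitrogen, 1 chlorine; one five-membered aromatic ring with 2 hetero atoms, one six-membered aromatic ring with 1 hetero atom), on a saturated chain carbon bound to a double-bonded chain carbon. Among the compounds with values here, it falls on a saturated chain carbon bound to a double-bonded chain carbon, the same place as the one measured step, an at least 4.4-fold higher number from compound 1 to compound 2 (0.64 log units; beyond the scatter). That step exchanged a bromine-bearing group for a chlorine-bearing one, and it shows that changes here can move this assay beyond the scatter. Within the data shown here, compound 3 keeps chlorine and gains fluorine, a change with no measured precedent. With compound 1 at 22600 nM as the only numerical anchor, a move of similar size towards stronger inhibition is expected. A second limit remains possible for compound 3. The expected change is an at least 2.5-fold lower number from compound 2 to compound 3 (0.39 log units; beyond the scatter). The estimate for compound 3 is 40000 nM, with an expected range of 12000 nM to 100000 nM.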

Compound 3, half-maximal inhibitory concentration: > 100000 nM
Compound 3 ended at the assay's limit; the forecaster's own chance of this, stated with the estimate: 40%; at least 2.5-fold (0.39 log units) between middle value and limit.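

In this assay compound 3 gives > 100000 nM, which is a limit of the assay and not a number. The step between compound 2 and compound 3 cannot be read, so adding two fluorines to the chlorine-bearing group gives no measurable change, and the series now stands at this point: the limit of > 100000 nM in this assay, at which 2 of the 3 values shown sit. Exchanging the bromine-bearing group for the group with two fluorines and one chlorine gives an at least 4.4-fold higher number from compound 1 to compound 3 (0.64 log units; beyond the scatter), making this the second group on the saturated chain carbon bound to a double-bonded chain carbon to lie beyond the scatter from the bromine-bearing group.

On these data alone, only compound 1 gives a number, and how far compound 2 and compound 3 lie from it remains open, as does which feature of its bromine-bearing group carries that reading. An amine or a carboxylic acid on this group, or a longer chain at this place, could show whether changes here can give a stronger inhibitor than compound 1.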